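The source may hold more compounds than are shown below. What is called first, only, known or untested is meant among the compounds shown, and "the series" means these compounds.

Series notes, step from compound 2 to compound 4.

Of the compounds shown here, three have been measured in an assay on isolated protein for inhibition of aldehyde dehydrogenase 1A1 (Homo sapiens), read by spectrophotometry, tested at 10 uM; on this read-out higher numbers stand for more inhibition at the one concentration tested (going by the name of the read-out) and lower numbers for less inhibition. Compound 1 `Cc1cccc(Cn2c(CN3CCN(C(=O)c4ccc(C(F)(F)F)cc4)CC3)nc3ccccc32)c1` gives 22.9%, compound 2 `O=C(C1CC1)N1CCN(Cc2nc3ccccc3n2Cc2ccccc2F)CC1` gives 40.7%, and compound 3 `Cc1ccc(C(=O)N2CCN(Cc3nc4ccccc4n3Cc3cccc(C)c3)CC2)cc1` gives 64.9%. On these numbers compound 2 stands second of three: compound 1 lies lower by a gap beyond the scatter, compound 3 lies higher by a gap beyond the scatter. Among the compounds with values here, the only single-point step measured so far is a number 42 percentage points higher from compound 1 to compound 3 (beyond the scatter), which concerns the aryl amide end of the core and not the group on the saturated chain carbon bound to the aromatic nitrogen.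

Compound 4 `O=C(C1CC1)N1CCN(Cc2nc3ccccc3n2CC2CC2)CC1` differs from compound 2 by cyclopropyl in place of 2-fluorophenyl on a saturated chain carbon bound to an aromatic nitrogen. Within the data shown here, no measured step in this assay touches this position, so the step from compound 1 to compound 3 gives no direct guide, and there is no ground to expect a change beyond the scatter in either direction. The estimate for compound 4 is therefore 36%, within 16% to 56%, the expected step being a number 4.7 percentage points lower from compound 2 to compound 4 (within the scatter).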

Compound 4, a percentage reported as inhibition, at one concentration (the size of the read-out at that concentration, not a potency): 21.2%
Beside the measured number, compound 4's estimate is 14.8 percentage points above it; the range from low to high includes it.
By their numbers in this assay, from the lowest: compounds 4 and 1 (each within the scatter of the next); then compound 2; then compound 3.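

Within the data shown here, the group on the saturated chain carbon bound to an aromatic nitrogen is not a silent part of the series: in this assay the change gives a number 19.5 percentage points lower from compound 2 to compound 4 (beyond the scatter), the first measured step at this position. The step holds the cyclopropyl carbonyl end fixed, so it belongs to the change from 2-fluorobenzyl to cyclopropylmethyl alone. That change replaces the aromatic ring, removes the fluorine and reduces the heavy atom count all at once, and no information here bears on why the number falls.

Which of these differences carries the step stays open, and plain benzyl or a longer chain such as n-butyl at this position would help to separate them. As far as these compounds go, whether the step keeps its size alongside the aryl amide end of compound 3 also remains unknown.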